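A benzyl for a phenyl on the triazole nitrogen

A few compounds are considered here, and "the series" means these few. Any claim that something is new, unique, unknown or untested is made for them only; others in the source may bear on it.

Of the compounds shown here, three sharing a piperazine dithiocarbamate core have been tested in a functional assay on PC-3 cells (Homo sapiens) for inhibition, read by MTT assay, with a stated time of 72 h; a lower number here means a stronger inhibitor, a higher number a weaker inhibitor. Compound 1 `COc1ccc(-n2cc(CSC(=S)N3CCN(C(=O)OC(C)(C)C)CC3)nn2)cc1` gives only a limit, > 128000 nM, the top of the range this assay reports (the limit of > 128000 nM in this assay, at which 1 of the 3 values shown sits). Compound 2 `CC(C)(C)OC(=O)N1CCN(C(=S)SCc2cn(Cc3cc(=O)oc4cc(O)ccc34)nn2)CC1` gives 36800 nM in this assay, and compound 3 `O=C(OCc1ccccc1)N1CCN(C(=S)SCc2cn(Cc3ccccc3F)nn2)CC1` gives 68300 nM. Compound 4 `CC(C)(C)OC(=O)N1CCN(C(=S)SCc2cn(Cc3ccc(Cl)cc3)nn2)CC1` has not been measured; it differs from compound 1 by 4-chlorobenzyl in place of 4-methoxyphenyl on an aromatic nitrogen, in words 4-chlorobenzyl in place of 4-methoxyphenyl on an aromatic nitrogen. With compound 1 standing at a limit, the true size of the step is open. Compound 4 is expected to be a somewhat stronger inhibitor, with an expected step of an at least 2.1-fold lower number from compound 1 to compound 4 (0.32 log units; beyond the scatter) beyond the scatter. The estimated value for compound 4 is 60000 nM, within 25000 nM to 140000 nM.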

Compound 4, half-maximal inhibitory concentration: > 128000 nM
Compound 4: no number, only a limit; the forecaster's own chance of this, stated with the estimate: 30%; middle value at least 2.1-fold (0.32 log units) away from the limit.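

In this assay, compound 1 and compound 4 both stand at a limit, so the step between them cannot be read: the limit of > 128000 nM in this assay, at which 2 of the 4 values shown sit.

From the compounds shown here alone, whether 4-chlorobenzyl in place of 4-methoxyphenyl changes inhibition at all, and by how much, stays open.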